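Aryl swap at the shared core: antiproliferative series

The source may hold more compounds than are shown below. What is called first, only, known or untested is meant among the compounds shown, and "the series" means these compounds.

Measured so far:
compound 1 `c1ccc(-c2cc(-c3cccs3)cc(-c3ccco3)n2)cc1` — 118000 nM
compound 2 `C(=C/c1ccco1)\c1cc(-c2ccco2)cc(-c2cccs2)n1` — 118000 nM

In a functional assay on SK-OV-3 cells (Female gonad, Homo sapiens) for antiproliferative activity (a higher number here means that more compound is needed for the effect, a lower number that less compound is needed), compound 1 gives 118000 nM and compound 2 gives 118000 nM. Compound 1 stands level with compound 2; the two values lie within the scatter of each other. Compound 3 `c1coc(-c2cc(-c3cccs3)cc(-c3ccco3)n2)c1` is not yet measured. It differs from compound 1 by furan-2-yl in place of phenyl on an aromatic carbon. Among the compounds with values here, no step between two measured compounds is available, so the effect of this change is not anchored; with compound 1 and compound 2 giving the same reading, no step beyond the scatter is expected. Compound 3 is estimated at 118000 nM, range 50000 nM to 280000 nM, an expected step of no change at the digits printed from compound 1 to compound 3 (within the scatter).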

Compound 3, half-maximal effective concentration: 118000 nM
Compound 3: middle estimate and measured number agree at the digits printed, and the stated range covers the measured number.
By their numbers in this assay, from the lowest: compounds 1, 2 and 3 (each within the scatter of the next).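

In this assay, furan-2-yl in place of phenyl on an aromatic carbon next to the ring nitrogen gives no change at the digits printed from compound 1 to compound 3 (within the scatter). Within the data shown here, this is the first step that can be read directly: at this position the two aromatic rings read alike, and the hydrogen-bond acceptor that enters with furan-2-yl brings no shift beyond the scatter. No data at hand bear on why the two groups read alike.

Still open, as far as these compounds go, is whether any group at this position moves the reading, for example an amine or a carboxylic acid. From the compounds shown here alone, the same swap at the other aryl positions of the shared core also remains open.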